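Alkoxy variation on the shared core: toward cyclopentylmethoxy

The compounds below may be only part of what the source reports. "The series", "measured", "known", "first", "only" and "open" are said of these compounds alone.

Measured so far:
compound 1, `CCN(CC)C(=O)Cc1c(-c2ccc(OC(C)C)cc2)nn2c(C)cc(C)nc12`, 2.2 nM
compound 2, `CCN(CC)C(=O)Cc1c(-c2ccc(OCC3CC3)cc2)nn2c(C)cc(C)nc12`, 3 nM

Both compounds were tested in an assay on isolated protein (kidney, strain Wistar) for displacement of a labelled ligand from Translocator protein (Rattus norvegicus), read by scintillation counting, with a stated time of 90 min; a lower number here means a stronger inhibitor, a higher number a weaker inhibitor. Compound 2 gives the highest of the two numbers in this assay, but its nearest neighbour, compound 1, sits only a 1.4-fold higher number from compound 1 to compound 2 (0.13 log units; within the scatter) away, so the two cannot be told apart. That single step, cyclopropylmethyl in place of isopropyl on an oxygen on an aromatic ring, is the only one that bears on the next compound.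

Compound 3, `CCN(CC)C(=O)Cc1c(-c2ccc(OCC3CCCC3)cc2)nn2c(C)cc(C)nc12`, differs from compound 2 by cyclopentyl in place of cyclopropyl on a saturated chain carbon bound to an oxygen on an aromatic ring. Among the compounds with values here, the one measured step in this direction was within the scatter, so no movement beyond the scatter is expected from compound 2 to compound 3, with the estimate leaning slightly toward a higher number, a step of a 1.3-fold higher number from compound 2 to compound 3 (0.12 log units; within the scatter). For compound 3 the expected value in this assay is 4 nM, within the range 1.5 nM to 12 nM.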

Compound 3, inhibition constant: 2.1 nM
For compound 3 the middle estimate is 1.9-fold (0.28 log units) above the measured one; measured number inside the range.
By their numbers in this assay, from the lowest: compounds 3, 1 and 2 (each within the scatter of the next).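

In this assay, going from a three-membered to a five-membered carbon ring on the saturated chain carbon bound to an oxygen on an aromatic ring gives no step beyond the scatter (a 1.4-fold lower number from compound 2 to compound 3 (0.15 log units; within the scatter)). The comparison with the open-chain isopropyl group reads the same (a 1.0-fold lower number from compound 1 to compound 3 (0.02 log units; within the scatter)), so compounds 1, 2 and 3 cannot be told apart, and this position accepts all three groups with the added ring carbons leaving no readable trace. No evidence on hand explains this flat result.

As far as these compounds go, it remains open whether a group on this oxygen that contains something other than carbon, such as an amine or a carboxylic acid, would move the number beyond the scatter. From the compounds shown here alone, a longer straight chain, such as n-hexyl, is equally open.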